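Indene analogue of compound 2: expected binding

The source may report more compounds than this note shows. Statements on the series, on what has been measured and on what is new or still open speak of the compounds shown alone.

Going by the values given here, compound 2 `c1ccc2c(c1)CC(CCN1CCN(c3cccc4c3OCCO4)CC1)C2` gives 692 nM in an assay on isolated protein for binding affinity to 5-hydroxytryptamine receptor 1B (Rattus norvegicus) (on this read-out lower numbers stand for stronger inhibition and higher numbers for weaker inhibition), and stands highest of the two numbers measured so far; its nearest neighbour, compound 1 `c1ccc2c(c1)CC2CCCN1CCN(c2cccc3c2OCCO3)CC1`, gives 646 nM in this assay. Compound 3 `C1=C(CCN2CCN(c3cccc4c3OCCO4)CC2)Cc2ccccc21` differs from compound 2 by a group of 9 heavy atoms (9 carbon; one five-membered non-aromatic ring of carbon only, one six-membered aromatic ring of carbon only) in place of a group of 9 heavy atoms (9 carbon; one five-membered non-aromatic ring of carbon only, one six-membered aromatic ring of carbon only), on a saturated chain carbon, two bonds along the chain from an amine nitrogen in a ring. Among the compounds with values here, the only measured step, a 1.1-fold higher number from compound 1 to compound 2 (0.03 log units; within the scatter), swapped the same kind of attachment and moved the number hardly at all, so little beyond the scatter is expected for the step from compound 2 to compound 3, estimated as a 1.1-fold lower number from compound 2 to compound 3 (0.03 log units; within the scatter). Compound 3 is therefore expected to give about 650 nM in this assay, within 300 nM to 1400 nM.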

Compound 3, inhibition constant: 933 nM
Compound 3: the middle estimate sits 1.4-fold (0.16 log units) below what was measured, and the stated range covers the measured number.
By their numbers in this assay, from the lowest: compounds 1, 2 and 3 (each within the scatter of the next).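

The double bond outside aromatic rings leaves the number essentially where it was (a 1.3-fold higher number from compound 2 to compound 3 (0.13 log units; within the scatter)), and the comparison with the four-membered-ring group in compound 1 also stays small (a 1.4-fold higher number from compound 1 to compound 3 (0.16 log units; within the scatter)). In this assay, all three carbon-only groups at this place therefore read as one level, so neither ring size nor this unsaturation has yet separated the compounds. No supporting measurement accompanies these numbers.

Still open, from the compounds shown here alone, is whether a hydroxyl or an amine on the five-membered ring would move the number beyond the scatter. Going by these compounds, a longer chain between the ring and the amine nitrogen remains an equally open question.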